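Aryl urea series: chloro in place of cyano on the phenyl

This account rests on a few compounds, and the source may have more. Where it says the series, first, only, none or still open, it means among the compounds named here.

Measured so far:
compound 1 `CC1(C)CC(NC(=O)Nc2cccc(C#N)c2)c2cc(NS(C)(=O)=O)ccc2O1` — 9300 nM
compound 2 `CCS(=O)(=O)Nc1ccc2c(c1)C(NC(=S)Nc1cccc(C#N)c1)CC(C)(C)O2` — 12100 nM
compound 3 `CCS(=O)(=O)Nc1ccc2c(c1)C(NC(=O)Nc1cccc(C#N)c1)CC(C)(C)O2` — 9500 nM

In a functional assay on thoracic aorta (Rattus norvegicus) for inhibition (a higher number here means that more compound is needed for the effect, a lower number that less compound is needed), compound 3 gives 9500 nM and stands second highest of the three numbers; its nearest neighbour is compound 1 and its furthest is compound 2, and both gaps sit within the scatter. Going by the values given here, the only single-point step among the measured compounds is a 1.0-fold higher number from compound 1 to compound 3 (0.01 log units; within the scatter), which concerns the sulfonamide side of the shared core and says nothing about the phenyl urea. Compound 2 and compound 3 differ at the urea carbonyl; compound 2 gives 12100 nM in this assay, and that pair is not a listed step.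

Compound 4 `CCS(=O)(=O)Nc1ccc2c(c1)C(NC(=O)Nc1cccc(Cl)c1)CC(C)(C)O2` carries the change (chloro in place of cyano on an aromatic carbon). Among the compounds with values here, no measured step touches this position, so there is no precedent for its size or direction. The working expectation is therefore a step of no change at the digits printed from compound 3 to compound 4 (within the scatter), that is, nothing beyond the scatter. Compound 4 is accordingly estimated at 9500 nM in this assay, with a range from 4000 nM to 23000 nM.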

Compound 4, half-maximal effective concentration: 17200 nM
Estimate against measurement, compound 4: 1.8-fold (0.26 log units) below, within the range that was stated.
By their numbers in this assay, from the lowest: compounds 1, 3, 2 and 4 (each within the scatter of the next).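

In this assay the phenyl substituent of the urea now has its first step, with a 1.8-fold higher number from compound 3 to compound 4 (0.26 log units; within the scatter) for the exchange of 3-cyanophenyl to 3-chlorophenyl. At this place on the aromatic ring, the nitrile, with its triple bond and hydrogen-bond acceptor, can therefore give way to chloro without a step beyond the scatter. No supporting measurement bears on the reason for the size of this step.

On these data alone, whether any group on this aromatic carbon gives a step beyond the scatter remains open, and a methoxy group, an amine or a carboxylic acid there would test it. As far as these compounds go, it is also open whether the same exchange reads alike with the thiourea of compound 2 or the shorter sulfonamide chain of compound 1.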